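This account rests on a few compounds, and the source may have more. Where it says the series, first, only, none or still open, it means among the compounds named here.

Measured so far:
compound 1 `CN(Cc1cn(CC(O)COC(=O)C2CCCCC2)nn1)CC1CCCCC1`, 18%
compound 2 `CCCCC(O)Cn1cc(CN(C)CC2CCCCC2)nn1`, 47%
compound 3 `CCCCN(CCCC)Cc1cn(CC(O)COCc2ccccc2)nn1`, 6%

In an assay on nucleic acid for inhibition of Nucleic Acid, read by fluorescence, tested at 100 uM (a lower number here means less inhibition, a higher number more inhibition at the concentration tested (going by the name of the read-out)), compound 3 gives the lowest of the three numbers; compound 1 sits a number beyond the scatter above it, and compound 2 lies furthest above. The step to compound 4 `CN(Cc1cn(CC(O)COCc2ccccc2)nn1)CC1CCCCC1` is (cyclohexylmethyl)(methyl)amino in place of dibutylamino on a saturated chain carbon bound to an aromatic carbon. Within the data shown here, no measured pair differs in this amine alone, so no measured step bears directly on it. Among the measured compounds shown here, the one measured step, a number 29 percentage points higher from compound 1 to compound 2 (beyond the scatter), changes the other chain and leaves the amine untouched. What can be said is that both compounds carrying the entering amine, compound 1 and compound 2, give numbers higher than compound 3, while compound 1 and compound 4 share that amine and differ only in the other chain. A small rise is therefore expected, a number 10 percentage points higher from compound 3 to compound 4 (within the scatter), though with the scatter of this assay a step within the noise is also plausible. The estimate for compound 4 is 16%, with a range from 3% to 34%.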

Compound 4, a percentage reported as inhibition, at one concentration (the size of the read-out at that concentration, not a potency): 6%
Beside the measured number, compound 4's estimate is 10 percentage points above it; the range from low to high includes it.
By their numbers in this assay, from the lowest: compounds 3 and 4 (each within the scatter of the next); then compound 1; then compound 2.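

In this assay, (cyclohexylmethyl)(methyl)amino in place of dibutylamino on a saturated chain carbon bound to an aromatic carbon gives no change at the digits printed from compound 3 to compound 4 (within the scatter), so with the benzyloxy chain held constant the two amines are not told apart. With (cyclohexylmethyl)(methyl)amino held constant, the other chain does separate the compounds: benzyl in place of cyclohexylcarbonyl gives a number 12 percentage points lower from compound 1 to compound 4 (beyond the scatter), and benzyloxy in place of propyl gives a number 41 percentage points lower from compound 2 to compound 4 (beyond the scatter). Nothing available accounts for any of these steps.

Open, as far as these compounds go, is whether the two amines would also match on the propyl chain of compound 2 or on the ester chain of compound 1. Also open, from the compounds shown here alone, is what a morpholine or a primary amine would do at this place.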